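Trimethoxyphenyl in Place of 3,5-Dibromo-4-hydroxyphenyl

The source may hold more compounds than are shown below. What is called first, only, known or untested is meant among the compounds shown, and "the series" means these compounds.

In a functional assay on PC-3 cells (Homo sapiens) for cytotoxicity, read by MTT assay, with a stated time of 72 h (on this read-out higher numbers stand for weaker inhibition and lower numbers for stronger inhibition), compound 1 (`O=C(/C=C/c1cccc(Cl)c1Cl)Nc1cc2c(Nc3ccc(F)c(Cl)c3)ncnc2cc1O[C@H]1CCOC1`) gives 27500 nM and compound 2 (`COc1ccc(OC)c(/C=C/C(=O)Nc2cc3c(Nc4ccc(F)c(Cl)c4)ncnc3cc2O[C@H]2CCOC2)c1`) gives 8730 nM while compound 3 (`O=C(/C=C/c1cc(Br)c(O)c(Br)c1)Nc1cc2c(Nc3ccc(F)c(Cl)c3)ncnc2cc1O[C@H]1CCOC1`) gives 25500 nM on the same read-out. Compound 3 shares the high end of this set (a 1.1-fold lower number from compound 1 to compound 3 (0.03 log units; within the scatter)) and stands clear of the low end (a 2.9-fold higher number from compound 2 to compound 3 (0.47 log units; beyond the scatter)) on these numbers. Compound 4 (`COc1ccc(/C=C/C(=O)Nc2cc3c(Nc4ccc(F)c(Cl)c4)ncnc3cc2O[C@H]2CCOC2)c(OC)c1OC`) makes one change (2,3,4-trimethoxyphenyl in place of 3,5-dibromo-4-hydroxyphenyl on a double-bonded chain carbon bound to a double-bonded chain carbon) and so carries methoxy groups. Going by the values given here, compound 2 is the only measured compound with methoxy groups, and reaching it gave a modest drop (a 3.2-fold lower number from compound 1 to compound 2 (0.50 log units; beyond the scatter)) of similar size to the gap from compound 3. A modest step to a lower number is therefore expected, resting on that single example. The expected step is a 2.3-fold lower number from compound 3 to compound 4 (0.37 log units; beyond the scatter) in this estimate. For compound 4 the estimated value is 11000 nM with an expected range from 5000 nM to 25000 nM on this reading.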

Compound 4, half-maximal inhibitory concentration: 7670 nM
The estimate for compound 4 lay 1.4-fold (0.16 log units) above the measured number; measured number inside the range.
By their numbers in this assay, from the lowest: compounds 4 and 2 (each within the scatter of the next); then compounds 3 and 1 (each within the scatter of the next).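

In this assay the second methoxy-bearing group repeats the drop seen once before, with a 3.3-fold lower number from compound 3 to compound 4 (0.52 log units; beyond the scatter) and a 3.6-fold lower number from compound 1 to compound 4 (0.55 log units; beyond the scatter). Adding to the methoxy pattern changes little, as a 1.1-fold lower number from compound 2 to compound 4 (0.06 log units; within the scatter), so 2,3,4-trimethoxyphenyl and 2,5-dimethoxyphenyl cannot be told apart here, and both stand apart from the halogen-bearing groups of compound 1 and compound 3. Nothing measured here accounts for this difference. The compounds shown leave open whether a single methoxy group would suffice. They also leave open how an amine or a carboxylic acid on this phenyl ring would read.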